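Acetyl to Nitro: What to Expect of Compound 3

A few compounds are considered here, and "the series" means these few. Any claim that something is new, unique, unknown or untested is made for them only; others in the source may bear on it.

Of the compounds shown here, two have so far been tested in a functional assay on A549 cells (Homo sapiens) for cytotoxicity, read by sulforhodamine B assay, with a stated time of 48 h; on this read-out lower numbers stand for stronger inhibition and higher numbers for weaker inhibition. Compound 1 `COc1ccc2c(c1)c(/C=N/O)cn2Cc1cn([C@@H]2O[C@H](COC(C)=O)[C@@H](OC(C)=O)[C@H](OC(C)=O)[C@H]2OC(C)=O)nn1` gives > 200000 nM, which is a limit of the assay and not a number. Compound 2 `CC(=O)OC[C@H]1O[C@@H](n2cc(Cn3cc(C(C)=O)c4ccccc43)nn2)[C@H](OC(C)=O)[C@@H](OC(C)=O)[C@@H]1OC(C)=O` gives > 200000 nM, again a limit rather than a measured value. For the measured compounds named here, compound 2 therefore stands nowhere definite on the scale: both values shown sit at the limit of > 200000 nM in this assay, at which 2 of the 2 values shown sit, and no step between measured compounds can be drawn from them.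

Compound 3 `CC(=O)OC[C@H]1O[C@@H](n2cc(Cn3cc([N+](=O)[O-])c4ccccc43)nn2)[C@H](OC(C)=O)[C@@H](OC(C)=O)[C@@H]1OC(C)=O` has not yet been measured. It differs from compound 2 by nitro in place of acetyl on an aromatic carbon, in words nitro in place of acetyl on an aromatic carbon, the change reading 3-acetyl-1H-indol-1-yl to 3-nitro-1H-indol-1-yl when cut one bond further out. With compound 2 at a limit, no direction can be read off for this change. The step is expected to be a number no higher from compound 2 to compound 3 (the limit leaves the size open), that is, none beyond the scatter. Compound 3 is accordingly estimated at 200000 nM, with a range from 50000 nM to 400000 nM, and is most likely to be reported as a limit once more.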

Compound 3, half-maximal inhibitory concentration: 93200 nM
For compound 3 the middle estimate is 2.1-fold (0.33 log units) above the measured one; measured number inside the range.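

In this assay compound 3 gives 93200 nM, the first value among the compounds shown that is a number and not a limit of the assay. As far as these compounds go, this shows that the group on this aromatic carbon, on the five-membered aromatic ring with 1 nitrogen, can move the read-out: nitro in place of acetyl gives an at least 2.1-fold lower number from compound 2 to compound 3 (0.33 log units; beyond the scatter), and the full size of that step stays open. The gain is confined to one compound, and the assay's limit still holds the other values shown: the limit of > 200000 nM in this assay, at which 2 of the 3 values shown sit.

The compounds shown leave open whether this step is particular to nitro or would also appear with another group on the same carbon, such as an amine, a carboxylic acid or a longer chain, and how far the number could fall with any of these. They also leave open whether nitro in place of the group at the matching place on the core of compound 1 would give a step of the same direction in this assay.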